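This account rests on a few compounds, and the source may have more. Where it says the series, first, only, none or still open, it means among the compounds named here.

Measured so far in a functional assay on A549 cells (Homo sapiens) for inhibition, read by MTT assay, with a stated time of 24 h; on this read-out higher numbers stand for weaker inhibition and lower numbers for stronger inhibition:

compound 1, `CCOC(=O)C1=Cc2ccccc2OC1(OCc1cn(CC(=O)Nc2cccc(Cl)c2)nn1)C(F)(F)F`: 12800 nM
compound 2, `CCOC(=O)C1=Cc2ccccc2OC1(OCc1cc(-c2ccc(Cl)cc2)no1)C(F)(F)F`: 19100 nM

Compound 1 stands lowest of the two numbers, yet the gap to compound 2 lies within the usual scatter of repeated measurements, so nothing separates the pair beyond that scatter. Both values sit in the weak range of this assay. Among the compounds with values here, no step between the two measured compounds is on record, as they differ in more than one place.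

Compound 3, `CCOC(=O)C1=Cc2ccccc2OC1(OCc1cn(-c2cccc(C(F)(F)F)c2)nn1)C(F)(F)F`, is the next member to be measured in this assay. Within the data shown here, its single difference from compound 1 is 3-(trifluoromethyl)phenyl in place of ((3-chlorophenyl)carbamoyl)methyl on an aromatic nitrogen. The change removes the hydrogen-bond donor and the hydrogen-bond acceptor of the leaving group and brings in three fluorine atoms on the entering group, with a similar count of heavy atoms overall.

Among the measured compounds shown here, with no measured step to lean on, the expected step of a 1.2-fold higher number from compound 1 to compound 3 (0.07 log units; within the scatter) is small, of no settled direction, and not beyond the scatter. Compound 3 is therefore estimated at 15000 nM in this assay. For compound 3 the expected range runs from 5000 nM to 45000 nM.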

Compound 3, half-maximal inhibitory concentration: > 150000 nM
Compound 3 ended at the assay's limit; the forecaster's own chance of this, stated with the estimate: 20%; middle value at least 10-fold (1.00 log units) away from the limit.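

Within the data shown here, the change on the aromatic nitrogen is the first single-place comparison, and it gives an at least 11-fold higher number from compound 1 to compound 3 (1.06 log units; beyond the scatter). The two groups have a similar heavy-atom count and each carries one carbon-only six-membered aromatic ring, yet the step is large, so in this assay this position does not tolerate every aromatic group of this size. Compound 3 reads > 150000 nM, which is a limit of the assay and not a number, and the full size of the step stays unknown because the read-out ends at that limit: the limit of > 150000 nM in this assay, at which 1 of the 3 values shown sits.

The single change also bundles several differences, as the carbamoyl methyl link, its hydrogen-bond donor and acceptor, and the chlorine all leave while the trifluoromethyl enters, and the compounds shown cannot assign the step to any one of these. A plain phenyl or a 3-chlorophenyl directly on the same nitrogen would separate the ring substituent from the link, and a 3-(trifluoromethyl)benzyl group or a carboxylic acid at this position remains an open question as well.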